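Adding a fluorine to the benzoyl ring of compound 2

A few compounds are considered here, and "the series" means these few. Any claim that something is new, unique, unknown or untested is made for them only; others in the source may bear on it.

Measured so far:
Compound 1 `Fc1ccc(C(SCCNC2CCN(Cc3ccc(Cl)cc3)CC2)c2ccc(F)cc2)cc1` gives 45.5 nM in an assay on membranes from Cortex for displacement of a labelled ligand from Sigma non-opioid intracellular receptor 1 (Cavia porcellus), read by scintillation counting, with a stated time of 120 min; on this read-out higher numbers stand for weaker inhibition and lower numbers for stronger inhibition.
Compound 2 `O=C(c1ccccc1)N1CCC(NCC[S+]([O-])C(c2ccc(F)cc2)c2ccc(F)cc2)CC1` gives 585 nM in this assay.

Of the two measured compounds, compound 2 gives the higher number, which on this read-out means weaker inhibition. Its nearest neighbour, compound 1, sits far below it, and that gap is beyond the usual scatter of repeated measurements, so compound 2 is clearly the weaker of the pair.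

Compound 3 `O=C(c1ccccc1F)N1CCC(NCC[S+]([O-])C(c2ccc(F)cc2)c2ccc(F)cc2)CC1` has not yet been measured in this assay. It differs from compound 2 in a single place: fluoro in place of hydrogen on an aromatic carbon. The fluorine enters on an aromatic carbon of a six-membered aromatic ring of carbon only, turning the benzoyl group into a (2-fluorophenyl)carbonyl group.

For the measured compounds named here, no measured pair shows a change of this kind, so there is no step to lean on. A single fluorine replacing a hydrogen is a small change, and the expected step is a 1.2-fold lower number from compound 2 to compound 3 (0.07 log units; within the scatter), a shift no larger than the scatter, with no clear direction. For compound 3 the estimated value is therefore 500 nM, with a range from 180 nM to 1400 nM.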

Compound 3, inhibition constant: 1310 nM
Beside the measured number, compound 3's estimate is 2.6-fold (0.42 log units) below it; the measured number falls inside the stated range.
By their numbers in this assay, from the lowest: compound 1; then compound 2; then compound 3.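

In this assay, the swap of hydrogen for fluoro turns the benzoyl group into a (2-fluorophenyl)carbonyl group and gives a 2.2-fold higher number from compound 2 to compound 3 (0.35 log units; beyond the scatter), so on this read-out inhibition becomes modestly weaker. Compound 1 and compound 2 differ in more than one place, so this is the first step shown that isolates a single change, and it reveals that this aromatic carbon, ortho to a large group, does not tolerate even one added fluorine without a measurable loss. Nothing available here explains the loss, so the step records what happens at this position but not the reason for it.

The compounds shown leave open whether the loss belongs to this particular carbon or would also appear with fluoro elsewhere on the same ring. They also leave open whether a different group at this place, such as chloro, methyl or methoxy, would weaken inhibition further, leave it unchanged or strengthen it.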